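Removing a methoxy group: effect on cell growth inhibition

This account rests on a few compounds, and the source may have more. Where it says the series, first, only, none or still open, it means among the compounds named here.

Measured so far:
- Compound 1, `COc1cccc(C(=O)/C=C/c2cc(Br)cc(OC)c2O)c1`: 33.5%
- Compound 2, `COc1cccc(C(=O)/C=C/c2cc(Br)ccc2O)c1`: 33.8%
- Compound 3, `COc1cccc(C(=O)CC2C(C#N)=C(N)Oc3c(OC)cc(Br)cc32)c1`: 32.3%

All three were tested in an ADME assay on MCF-10A cells (Homo sapiens) for cytotoxicity, read by sulforhodamine B assay, with a stated time of 72 h, tested at 10 uM; a higher number here means a stronger effect of the compound at the concentration tested, a lower number a weaker effect. Compound 1 and compound 2 differ in one place: hydrogen in place of methoxy on an aromatic carbon. That change gave a number 0.3 percentage points higher from compound 1 to compound 2 (within the scatter). Compound 3 rests on a different core than compound 1; the difference between the two cores is not broken down here. Compound 4, `COc1cccc(C(=O)CC2C(C#N)=C(N)Oc3ccc(Br)cc32)c1`, has not yet been measured. It differs from compound 3 by the same kind of change: hydrogen in place of methoxy on an aromatic carbon. Around the place it sits ortho to a fused ring and meta to a fused ring, whereas in compound 1 the group sat ortho to a hydroxy group and meta to a large group. Because the earlier step of a number 0.3 percentage points higher from compound 1 to compound 2 (within the scatter) stayed within the scatter, the step of a number 0.2 percentage points higher from compound 3 to compound 4 (within the scatter) is expected to be equally small in this assay. Compound 4 is therefore estimated at 32.5%, most likely between 22% and 43%.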

Compound 4, a percentage reported as activity, at one concentration (the size of the read-out at that concentration, not a potency): 101%
Beside the measured number, compound 4's estimate is 68.5 percentage points below it, outside the stated range (above it).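

In this assay, putting hydrogen in place of methoxy on the core of compound 3 gave a number 68.7 percentage points higher from compound 3 to compound 4 (beyond the scatter), so the same change did not behave alike on the two cores: the same change on two cores in this assay, a number 0.3 percentage points higher (within the scatter) from compound 1 to compound 2 and a number 68.7 percentage points higher (beyond the scatter) from compound 3 to compound 4, 68.4 percentage points apart, beyond the scatter of two such steps. A small step on the core of compound 1 is therefore no safe guide to this change on the core of compound 3. The result does not show why the two cores differ, and two pairs give no rule for any further core.

The compounds shown leave open what other groups at this place would do on the core of compound 3. An ethoxy group or a fluoro group there could give a number close to that of compound 3, close to that of compound 4, or somewhere in between.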